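A Bromo to Chloro Swap on an Allyloxy Compound

A few compounds are considered here, and "the series" means these few. Any claim that something is new, unique, unknown or untested is made for them only; others in the source may bear on it.

In a functional assay on Hep cells (Homo sapiens) for cytotoxicity, read by sulforhodamine B assay, with a stated time of 48 h (a lower number here means a stronger inhibitor, a higher number a weaker inhibitor), two compounds have been measured so far. Compound 1 `O=C(c1cccnc1)c1cc(Cl)ccc1O` gives 27000 nM, and compound 2 `C=CCOc1ccc(Br)cc1C(=O)c1cccnc1` gives 78000 nM. Compound 2 therefore holds the higher of the two numbers, which marks it as the weaker inhibitor of the pair, and the gap lies beyond the usual scatter.

The next compound, compound 3 `C=CCOc1ccc(Cl)cc1C(=O)c1cccnc1`, still awaits measurement. It departs from compound 2 at a single place: chloro in place of bromo on an aromatic carbon. The exchanged atom sits para to an allyloxy group. Going by the values given here, no measured pair in this small set shows such a swap, so the expectation has no direct precedent. With compound 2 at 78000 nM as the starting point, no step beyond the scatter is expected in this assay. The expected change amounts to a 1.1-fold lower number from compound 2 to compound 3 (0.05 log units; within the scatter). For compound 3 the estimated value is 70000 nM, with an expected range from 35000 nM to 140000 nM.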

Compound 3, half-maximal inhibitory concentration: > 100000 nM
Compound 3 ended at the assay's limit; the forecaster's own chance of this, stated with the estimate: 10%; at least 1.4-fold (0.15 log units) between middle value and limit.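

In this assay compound 3 gives > 100000 nM, which is a limit of the assay and not a number: the limit of > 100000 nM in this assay, at which 1 of the 3 values shown sits. On the aromatic carbon para to the allyloxy group, chloro in place of bromo gives an at least 1.2-fold higher number from compound 2 to compound 3 (0.10 log units; that floor lies within the scatter), so the swap brings no gain in strength, but that floor cannot show whether the halogen matters here at all. Going by these compounds alone, the new compound also provides the first comparison at the oxygen, where allyl in place of hydrogen gives an at least 3.7-fold higher number from compound 1 to compound 3 (0.56 log units; beyond the scatter), making compound 3 a weaker inhibitor than compound 1 in this chloro series by a margin beyond the scatter, a step that compound 1 and compound 2 could not show because they differ in two places.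

On these data alone, how far compound 3 lies past the limit stays open, and with it the true size of the halogen step. Also open, as far as these compounds go, is whether a methyl group or a longer chain on that oxygen would act as allyl does, and whether fluoro or an amine on the halogen's carbon would move the number within the range this assay can read.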